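The compounds below may be only part of what the source reports. "The series", "measured", "known", "first", "only" and "open" are said of these compounds alone.

Of the compounds shown here, two have numbers so far. Compound 1 `COc1cccc(NC(=O)COc2ccc3cc(/C=C4/SC(=O)NC4=O)ccc3c2)c1` gives, in an assay on isolated protein for inhibition of histone deacetylase 8 (Homo sapiens), with a stated time of 1 h (a lower number here means a stronger inhibitor, a higher number a weaker inhibitor), a value of 7600 nM. Compound 2 `Cc1cccc(NC(=O)COc2ccc3cc(/C=C4/SC(=O)NC4=O)ccc3c2)n1` gives in this assay a value of 7500 nM. Going by the values given here, the one step between them, a 1.0-fold lower number from compound 1 to compound 2 (0.01 log units; within the scatter), lies within the scatter, so compound 2 stands level with compound 1 on the two numbers at hand; no order between them can be read.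

Compound 3 `O=C(COc1ccc2cc(/C=C3/SC(=O)NC3=O)ccc2c1)Nc1ccc(Br)cc1` differs from compound 2 in one place: 4-bromophenyl in place of 6-methylpyridin-2-yl on an amide-type nitrogen. Among the compounds with values here, no measured step touches the same position with a 4-bromophenyl group; the only step on record at that nitrogen, from compound 1 to compound 2, exchanged one aryl group for another and moved nothing beyond the scatter. On that basis no step beyond the scatter is expected in this assay for this exchange either, in neither direction, though the range is kept wide because a single step is a thin basis. The estimate for compound 3 is therefore 7000 nM, with a range from 2500 nM to 20000 nM, meaning an expected step of a 1.1-fold lower number from compound 2 to compound 3 (0.03 log units; within the scatter).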

Compound 3, half-maximal inhibitory concentration: 16000 nM
For compound 3 the middle estimate is 2.3-fold (0.36 log units) below the measured one; measured number inside the range.
By their numbers in this assay, from the lowest: compounds 2 and 1 (each within the scatter of the next); then compound 3.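

The aryl group on the amide-type nitrogen is not interchangeable in this assay: with 4-bromophenyl at this position there is a 2.1-fold higher number from compound 2 to compound 3 (0.33 log units; beyond the scatter), and against the other aryl group there is a 2.1-fold higher number from compound 1 to compound 3 (0.32 log units; beyond the scatter). This position can therefore move the number beyond the scatter, which the exchange of 3-methoxyphenyl for 6-methylpyridin-2-yl did not show, and both new steps, though modest, run towards a weaker inhibitor. Nothing on hand accounts for this shift.

As far as these compounds go, it remains open whether the shift belongs to the bromine atom or to the 4-bromophenyl group as a whole, and a plain phenyl or a 4-chlorophenyl group on the same nitrogen would separate these two readings. Also open, from the compounds shown here alone, is how far the number moves, and in which direction, with a group of another kind at this position, such as a saturated chain ending in an amine or a carboxylic acid.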